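The compounds below may be only part of what the source reports. "The series", "measured", "known", "first", "only" and "open" are said of these compounds alone.

Three compounds have been measured in a functional assay on HEK293 cells for antagonist activity at metabotropic glutamate receptor 5 (Homo sapiens), read by FLIPR and calcium flux; a higher number here means a weaker inhibitor, a lower number a stronger inhibitor:

Compound 1, `N#Cc1cccc(C(=O)NC2CCCC(NC(=O)c3ccccn3)C2)c1`: 531 nM
Compound 2, `CN(C)c1ccc(C(=O)N[C@H]2CCC[C@H](NC(=O)c3cccc(Cl)c3)C2)cc1`: 473 nM
Compound 3, `O=C(N[C@H]1CCC[C@H](NC(=O)C2CCCCC2)C1)c1cccc(Cl)c1`: 857 nM

Among these three numbers compound 1 stands second highest. Its nearest neighbour is compound 2, whose number is only slightly lower, and its furthest is compound 3, whose number is somewhat higher; both gaps lie within the usual scatter of repeated measurements. Among the compounds with values here, the one single-point step among the measured compounds is a 1.8-fold higher number from compound 2 to compound 3 (0.26 log units; within the scatter), which changes an aromatic group on a carbonyl carbon for a saturated ring and moves the number by less than the scatter.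

Compound 4, `N#Cc1cccc(C(=O)N[C@H]2CCC[C@H](NC(=O)c3ccccn3)C2)c1`, is the next compound. Compared with compound 1 it differs in the two compounds have the same atoms and bonds; at least one stereo element is drawn with a configuration in one of them and without one in the other: 2 of 2 stereo elements differ; a stereocentre at a saturated ring carbon is drawn without a configuration in compound 1 and S in compound 4; a stereocentre at a saturated ring carbon is drawn without a configuration in compound 1 and S in compound 4. In other words, compound 1 is drawn as a mixture of spatial arrangements of the shared core, while compound 4 is one defined arrangement of the same atoms and bonds. Within the data shown here, no measured step covers this kind of change. What can be said is that compound 2 and compound 3 carry the same drawn configuration as compound 4 and give numbers close to compound 1, so the defined arrangement is clearly an active one. If compound 1 is a mixture in which this arrangement does the work, compound 4 is expected to give a somewhat lower number, though a step within the scatter is also plausible; the expected step is a 1.6-fold lower number from compound 1 to compound 4 (0.21 log units; within the scatter). For compound 4 the estimate in this assay is 330 nM, with a range from 150 nM to 800 nM.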

Compound 4, half-maximal inhibitory concentration: > 10000 nM
Compound 4 was reported as a limit; the forecaster's own chance of this, stated with the estimate: 3%; middle value at least 30-fold (1.48 log units) from the limit.
By their numbers in this assay, from the lowest: compounds 2, 1 and 3 (each within the scatter of the next). At a limit, above all of these: compound 4.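

In this assay, the step is an at least 18-fold higher number from compound 1 to compound 4 (1.27 log units; beyond the scatter), so two compounds with the same atoms and bonds need not give the same result, and how the two saturated ring carbons are drawn matters a great deal for this pair. Going by these compounds, compound 4 gives > 10000 nM, which is a limit of the assay and not a number, so the true size of the step stays unknown. The large gap can be traced to one place only, and if compound 1 is a mixture, its 531 nM would have to come from some arrangement other than the one drawn in compound 4, since nothing else separates the pair: the fact that one of compounds 1 and 4 is drawn with a defined configuration and the other without, at the place where they differ

The compounds shown leave open which defined arrangement of the shared core accounts for the number of compound 1, and whether any single arrangement would give a lower number than the mixture. They also leave open whether a hydroxyl or a methoxy group in place of the nitrile would bring a measurable number back in the arrangement drawn in compound 4.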